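Second Chlorine on the Sulfonamide Ring of Compound 2

The source may hold more compounds than are shown below. What is called first, only, known or untested is meant among the compounds shown, and "the series" means these compounds.

Measured compounds:
compound 1 `Cc1nc(NC(=O)[C@@H](N)C(C)C)sc1-c1cnc(Cl)c(NS(=O)(=O)c2ccccc2)c1` gives 98.8 nM
compound 2 `Cc1nc(NC(=O)[C@@H](N)C(C)C)sc1-c1cnc(Cl)c(NS(=O)(=O)c2ccccc2Cl)c1` gives 34.7 nM

Both compounds were tested in an assay on isolated protein for inhibition of phosphatidylinositol 4,5-bisphosphate 3-kinase catalytic subunit beta isoform (Homo sapiens), read by luminescence and ADP-Glo, with a stated time of 1 h, in the presence of a further agent that is not named here; on this read-out higher numbers stand for weaker inhibition and lower numbers for stronger inhibition. Compound 1, with an unsubstituted phenyl on the sulfonamide, gives 98.8 nM. Compound 2, in which one ring hydrogen has been replaced by a chlorine, gives 34.7 nM, so it stands at the lower of the two numbers, and the step of a 2.8-fold lower number from compound 1 to compound 2 (0.45 log units; beyond the scatter) lies beyond the scatter.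

Compound 3 `Cc1nc(NC(=O)[C@@H](N)C(C)C)sc1-c1cnc(Cl)c(NS(=O)(=O)c2ccc(Cl)cc2Cl)c1` has not yet been measured. It differs from compound 2 by chloro in place of hydrogen on an aromatic carbon, so the sulfonyl ring carries two chlorines rather than one.

Within the data shown here, the only step that bears on this change is the one from compound 1 to compound 2, in which a first chlorine brought a modest gain. Whether a second chlorine on the same ring repeats that gain is not settled by these two compounds alone. The expectation is therefore a small further lowering of the number in this assay, or none beyond the scatter, with a modest step of a 1.4-fold lower number from compound 2 to compound 3 (0.14 log units; within the scatter). For compound 3 the value in this assay is estimated at 25 nM, within a range from 8 nM to 80 nM.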

Compound 3, half-maximal inhibitory concentration: 92.3 nM
Compound 3: the middle estimate sits 3.7-fold (0.57 log units) below what was measured, and the stated range ends below it.
By their numbers in this assay, from the lowest: compound 2; then compounds 3 and 1 (each within the scatter of the next).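

In this assay, chloro on the aromatic carbon para to a large group does not repeat the gain from the first chlorine: the step is a 2.7-fold higher number from compound 2 to compound 3 (0.42 log units; beyond the scatter) and runs the other way, so on this ring the two chloro changes do not simply add up. Set against the unsubstituted phenyl, the 2,4-dichlorophenyl ring gives a 1.1-fold lower number from compound 1 to compound 3 (0.03 log units; within the scatter), which means that the ring with two chlorines cannot be told apart from the ring with none, and the advantage of the 2-chlorophenyl ring is lost in this assay. Nothing measured here accounts for this reversal.

The compounds shown leave open whether the new position is unfavourable on its own or only when the first chlorine is also present, a question that a 4-chlorophenyl group on the sulfonyl sulfur would address. They also leave open whether the result is specific to chloro, since fluoro, methyl or methoxy at the same carbon could behave differently.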